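The source may report more compounds than this note shows. Statements on the series, on what has been measured and on what is new or still open speak of the compounds shown alone.

Measured so far:
compound 1 `Cc1ccnc(NC[C@@H]2CC3(CC3)CN2C(=O)c2nc(C)sc2-c2ccccc2)n1` — 7
compound 2 `Cc1nc(C(=O)N2CC3(CC3)C[C@H]2CNc2ncc(Cl)cn2)c(-c2ccccc2)s1` — 6.8
compound 3 `Cc1ccc(-c2ncccn2)c(C(=O)N2CC3(CC3)C[C@H]2CNc2cc(C(F)(F)F)ccn2)c1` — 7.8

In a functional assay on HEK293 cells for antagonist activity at Orexin receptor type 2 (Homo sapiens), read by FLIPR and calcium flux (a lower number here means a less potent compound, a higher number a more potent compound, by a factor of ten per unit of this negative logarithm), compound 3 gives 7.8, the highest of the three numbers; its gaps to compound 1 and to compound 2 both lie beyond the scatter. Compound 4 `Cc1ccc(-c2ncccn2)c(C(=O)N2CC3(CC3)C[C@H]2CNc2ccc(C(F)(F)F)cn2)c1` differs from compound 3 only in the aryl on the amine nitrogen: 5-(trifluoromethyl)pyridin-2-yl in place of 4-(trifluoromethyl)pyridin-2-yl on an amine nitrogen. Within the data shown here, the one measured step at this position, a number 0.20 log units lower from compound 1 to compound 2 (within the scatter), exchanged one pyrimidinyl for another and stayed within the scatter; no measured step moves a trifluoromethyl between positions of a pyridinyl, so the new change has no direct precedent. On that basis, no step beyond the scatter is expected, a number 0.10 log units lower from compound 3 to compound 4 (within the scatter). Compound 4 is therefore estimated at 7.7, with a range from 7.1 to 8.3.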

Compound 4, negative logarithm of the antagonist equilibrium constant: 6.6
For compound 4 the middle estimate is 1.10 log units above the measured one, outside the stated range (below it).
By their numbers in this assay, from the lowest: compounds 4, 2 and 1 (each within the scatter of the next, the first and the last beyond it); then compound 3.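

In this assay the amine nitrogen substituent proves sensitive to the placement of a single group, with 5-(trifluoromethyl)pyridin-2-yl in place of 4-(trifluoromethyl)pyridin-2-yl giving a number 1.20 log units lower from compound 3 to compound 4 (beyond the scatter) on an otherwise unchanged structure. Among these compounds, this is the first step beyond the scatter at this position, and the two groups match in every count, so only the place of the trifluoromethyl separates them. Nothing available here accounts for the loss. As far as these compounds go, it remains open whether the same change behaves alike on the core of compound 1. Also open, from the compounds shown here alone, is whether a nitrile or a methoxy in place of that trifluoromethyl would hold the level of compound 3.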